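The compounds below may be only part of what the source reports. "The series", "measured", "known", "first", "only" and "open" are said of these compounds alone.

Measured compounds:
Compound 1, `Fc1ccc2c(=S)cc(-c3ccccc3)oc2c1`, in an in vitro assay on BTI-TN-5B1-4 cells for inhibition of Amine oxidase [flavin-containing] A (Homo sapiens), tested at 100 uM; a lower number here means less inhibition, a higher number more inhibition at the concentration tested (going by the name of the read-out): 40%
Compound 2, `Fc1ccc(-c2cc(=S)c3ccccc3o2)cc1`, in this assay: "not active" (no number reported)

Compound 2 stands apart from compound 1 in that no number was reported for it; in this assay compound 2 is recorded only as "not active" (no number reported), so its position on the scale of inhibition cannot be given as a figure. Compound 1, which carries its fluoro on the fused ring system rather than on the pendant phenyl, gives 40% in this assay.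

The step to compound 3, `Fc1ccc(-c2cc(=S)c3ccc(F)cc3o2)cc1`, is a single change: fluoro in place of hydrogen on an aromatic carbon. Compound 3 thus combines the substitution of compound 2 with that of compound 1. No step between measured compounds is shown here, so the size of the effect cannot be read from a precedent. Given that compound 1 is the only measured compound with a number, a modest rise in inhibition for compound 3 is expected, though it may not exceed the scatter. Compound 3 is estimated to give 20% in this assay, within a range from 0% to 45%.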

Compound 3, a percentage reported as inhibition, at one concentration (the size of the read-out at that concentration, not a potency): "not active" (no number reported)
The entry for compound 3 holds no number; the estimate stays without a comparison.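

In this assay, for the compounds shown here, compound 2 and compound 3 are both recorded only as "not active", without a number, so no step between them can be read. Going by these compounds, how far the added fluoro shifts inhibition stays open, and no evidence at hand bears on this result.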